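The compounds below may be only part of what the source reports. "The series", "measured", "known", "first", "only" and "open" are said of these compounds alone.

Three compounds sharing one core were measured in a functional assay on A549 cells (Homo sapiens) for inhibition, read by MTT assay, with a stated time of 48 h; on this read-out lower numbers stand for stronger inhibition and higher numbers for weaker inhibition. Compound 1 `COc1ccc(/C=C/c2cc(OC)cc(OC)c2/C=C/C(=O)N2CCN(C)CC2)cc1` gives 4510 nM; compound 2 `COc1ccc(/C=C/c2cc(OC)cc(OC)c2/C=C/C(=O)N2CCCCC2C)cc1` gives 5770 nM; compound 3 `COc1ccc(/C=C/c2cc(OC)cc(OC)c2/C=C/C(=O)N2CCCCC2)cc1` gives 10600 nM, the highest of the three numbers. The steps leading to it were a 2.4-fold higher number from compound 1 to compound 3 (0.37 log units; beyond the scatter) and a 1.8-fold higher number from compound 2 to compound 3 (0.26 log units; within the scatter). Compound 4 `CCCCCCCCNC(=O)/C=C/c1c(/C=C/c2ccc(OC)cc2)cc(OC)cc1OC` differs from compound 3 at the same carbonyl carbon: octylamino in place of piperidin-1-yl on a carbonyl carbon. For the measured compounds named here, no measured step exchanges a ring for an open chain, so the change is only loosely covered; the two steps that touch this carbonyl carbon, a 2.4-fold higher number from compound 1 to compound 3 (0.37 log units; beyond the scatter) and a 1.8-fold higher number from compound 2 to compound 3 (0.26 log units; within the scatter), were small. The number for compound 4 is therefore expected to move little, with no clear direction, a 1.2-fold lower number from compound 3 to compound 4 (0.07 log units; within the scatter). Compound 4 is estimated at 9000 nM, within 3500 nM to 25000 nM.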

Compound 4, half-maximal inhibitory concentration: 8660 nM
Beside the measured number, compound 4's estimate is 1.0-fold (0.02 log units) above it, and the stated range covers the measured number.
By their numbers in this assay, from the lowest: compounds 1, 2, 4 and 3 (each within the scatter of the next, the first and the last beyond it).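

In this assay, for the compounds shown here, octylamino is the first group on this carbonyl carbon without a ring and the first with a hydrogen-bond donor, yet a 1.2-fold lower number from compound 3 to compound 4 (0.09 log units; within the scatter). The other two steps to the open chain are equally contained, with a 1.5-fold higher number from compound 2 to compound 4 (0.18 log units; within the scatter) and a 1.9-fold higher number from compound 1 to compound 4 (0.28 log units; within the scatter), so compound 4 lies within the scatter of all three ring-bearing compounds. Nothing available explains why this exchange changes the number so little.

Going by these compounds, it remains open whether a shorter chain such as butylamino would behave like octylamino. The same question stands for an octyl chain ending in an amine or a carboxylic acid.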